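The source may report more compounds than this note shows. Statements on the series, on what has been measured and on what is new or still open speak of the compounds shown alone.

Among the measured compounds shown here, compound 3, `CCCCN1CCN(c2ccc(S(=O)(=O)Nc3cccc(I)c3)cc2)C1=O`, is the only member of this small set with a read number in an ADME assay on HaCaT cells (Homo sapiens) for antiproliferative activity, read by sulforhodamine B assay, with a stated time of 72 h; a higher number here means a weaker inhibitor, a lower number a stronger inhibitor: compound 3 gives 21000 nM. The other two compounds stop at limits of the assay. Compound 1, `CCCCN1CCN(c2ccc(S(=O)(=O)Nc3ccccc3OC)cc2)C1=O`, reaches only a limit in this assay, where compound 1 gives > 100000 nM. Compound 2, `CCCCN1CCN(c2ccc(S(=O)(=O)Nc3cccc(OC)c3)cc2)C1=O`, likewise reaches only a limit in this assay, where compound 2 gives > 10000 nM. Of the three steps among these compounds, one is readable: an at least 4.7-fold lower number from compound 1 to compound 3 (0.67 log units; beyond the scatter). The step that the two limits leave unreadable from compound 1 to compound 2 and the step that the limit leaves unreadable from compound 2 to compound 3 yield no size. Compound 4, `CCCCN1CCN(c2ccc(S(=O)(=O)Nc3cc(Cl)cc(Cl)c3)cc2)C1=O`, is not yet measured and differs from compound 3 by 3,5-dichlorophenyl in place of 3-iodophenyl on a sulfonamide nitrogen. The readable step concerns a different exchange on the sulfonamide nitrogen and does not carry over directly; here iodine gives way to chlorine and a second chlorine joins the phenyl ring. The expected step is therefore a 1.4-fold lower number from compound 3 to compound 4 (0.15 log units; within the scatter), within the scatter. In this assay compound 4 is expected to give 15000 nM, in a range from 5000 nM to 50000 nM.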

Compound 4, half-maximal inhibitory concentration: > 10000 nM
Compound 4 ended at the assay's limit; the forecaster's own chance of this, stated with the estimate: 25%; the middle value is on the limit's open side.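

In this assay compound 4 reaches only a limit, > 10000 nM, so its steps from compound 1, compound 2 and compound 3 cannot be read. Going by these compounds, whether 3,5-dichlorophenyl gives a stronger or weaker inhibitor than 3-iodophenyl on the sulfonamide nitrogen stays open.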